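A few compounds are considered here, and "the series" means these few. Any claim that something is new, unique, unknown or untested is made for them only; others in the source may bear on it.

Measured so far:
- compound 1, `COc1ccccc1N1CCN(CCCNc2ccc(C(=O)N(C)C)cn2)CC1`: 25.1 nM
- compound 2, `CN(C)C(=O)c1cccnc1NCCCN1CCN(c2ccccc2O)CC1`: 5.01 nM

Both were tested in a functional assay for antagonist activity at Alpha-1A adrenergic receptor (Oryctolagus cuniculus); a higher number here means weaker binding, a lower number tighter binding. Compound 2 stands at the lower of the two numbers; compound 1 gives the higher one, and the gap between them lies beyond the usual scatter of this assay. The two compounds differ in more than one place, so no single change can be read from that gap.

Compound 3, `CC(C)c1ccccc1N1CCN(CCCNc2ncccc2C(=O)N(C)C)CC1`, has not yet been measured. It differs from compound 2 in one place: isopropyl in place of hydroxy on an aromatic carbon.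

Among the compounds with values here, no measured pair isolates this change, so the expectation rests on compound 2 alone. The step from compound 2 to compound 3 is estimated at a 6.0-fold higher number from compound 2 to compound 3 (0.78 log units; beyond the scatter), toward a higher number, modestly beyond the scatter. Compound 3 is therefore expected to give 30 nM, with a plausible range from 8 nM to 120 nM.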

Compound 3, dissociation constant: 0.398 nM
Compound 3: middle estimate off by 75-fold (1.88 log units), on the high side; the measured number lies below the stated range.
By their numbers in this assay, from the lowest: compound 3; then compound 2; then compound 1.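

Putting isopropyl in place of hydroxy on this aromatic carbon, ortho to a large group, tightens binding by a large margin (a 13-fold lower number from compound 2 to compound 3 (1.10 log units; beyond the scatter)). The hydroxy, with its hydrogen-bond donor and acceptor, is therefore not required for tight binding in this pair, and a group of three carbon atoms with neither a donor nor an acceptor is not merely tolerated here but gives the lower number. Nothing shown here gives a measured reason for this gain.

As far as these compounds go, whether a methyl, a tert-butyl or an amine on the same carbon would give a number as low as that of compound 3 remains open. So does whether the same swap would lower the number to a similar degree on the core of compound 1.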